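Cytotoxicity notes on the boronic ester pyrrole ketone series

A few compounds are considered here, and "the series" means these few. Any claim that something is new, unique, unknown or untested is made for them only; others in the source may bear on it.

Three members of the series have been taken through an ADME assay on L929 cells (Mus musculus) for cytotoxicity, read by resazurin assay, with a stated time of 72 h (on this read-out higher numbers stand for weaker inhibition and lower numbers for stronger inhibition), so far. Compound 1 `CC(=O)c1ccn(-c2ccc3c(c2)B(O)OC3)c1` carries a methyl on the carbonyl carbon. In this assay compound 1 gives > 10 ug/mL, which is a limit of the assay and not a number. Compound 2 `O=C(c1ccn(-c2ccc3c(c2)B(O)OC3)c1)c1ccccc1Cl` carries a 2-chlorophenyl in the same place. In this assay compound 2 gives > 10 ug/mL, again a limit. Compound 3 `O=C(c1ccc(F)cc1)c1ccn(-c2ccc3c(c2)B(O)OC3)c1` carries a 4-fluorophenyl on the carbonyl carbon. In this assay compound 3 gives > 10 ug/mL, also a limit. Because all three values sit at the limit of > 10 ug/mL in this assay, at which 3 of the 3 values shown sit, the steps among them cannot be sized: a step that the two limits leave unreadable from compound 1 to compound 2, a step that the two limits leave unreadable from compound 1 to compound 3 and a step that the two limits leave unreadable from compound 2 to compound 3 are each left unreadable by the two limits.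

Compound 4 `CC(=O)OCc1ccc(C(=O)c2ccn(-c3ccc4c(c3)B(O)OC4)c2)cc1` is not yet measured. It differs from compound 3 as follows: acetoxymethyl in place of fluoro on an aromatic carbon. For the measured compounds named here, since no measured step in this assay resolves to a readable size, there is no basis for expecting movement in either direction for compound 4. The expected step from compound 3 to compound 4 is therefore a step that the limit leaves unreadable from compound 3 to compound 4, that is, no step beyond the scatter. For compound 4 the estimated value in this assay is 15 ug/mL, with an expected range from 7 ug/mL to 40 ug/mL, and most likely the result will again be reported only as a limit.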

Compound 4, half-maximal inhibitory concentration: 10 ug/mL
Estimate against measurement, compound 4: 1.5-fold (0.18 log units) above, and the stated range covers the measured number.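

In this assay, for the compounds shown here, compound 4 gives 10 ug/mL as the only value that is a number and not a limit. Compound 3 gives > 10 ug/mL as a limit of the assay, and acetoxymethyl in place of fluoro, on an aromatic carbon para to a large group, gives a number no higher from compound 3 to compound 4 (the limit leaves the size open) in this series. This position therefore takes the larger acetoxymethyl and yields a readable number, though the size of the change stays open and the series remains mostly limits: the limit of > 10 ug/mL in this assay, at which 3 of the 4 values shown sit.

The compounds shown leave open whether the number goes with the whole acetoxymethyl or with only a part of it, which a hydroxymethyl, a carboxylic acid or an amine at the same place could help to separate. The steps among compound 1, compound 2 and compound 3 cannot be read, so the carbonyl substituents offer no sized change against which the step at this position could be set.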